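Aryl ester swap on the shared core: plasma half-life

The source may hold more compounds than are shown below. What is called first, only, known or untested is meant among the compounds shown, and "the series" means these compounds.

For the measured compounds named here, compound 3 `CC(=O)Oc1ccccc1C(=O)O[C@H]1CO[C@H]2[C@@H]1OC[C@H]2OC(=O)c1cccc(C)c1` gives 0.165 h in an ADME assay on a cell-free system (plasma, Homo sapiens) for metabolic stability, with Plasma (Rattus norvegicus) as the target, read by HPLC, at pH 7.4 (on this read-out lower numbers stand for a shorter-lived compound and higher numbers for a longer-lived compound), the highest of the three numbers measured so far. Compound 1 `CCC(=O)O[C@@H]1CO[C@H]2[C@@H]1OC[C@@H]2OC(=O)c1ccccc1OC(C)=O` gives 0.0608 h and compound 2 `CC(=O)Oc1ccccc1C(=O)O[C@H]1CO[C@H]2[C@@H]1OC[C@H]2OC(=O)c1ccccc1C` gives 0.035 h in this assay; the steps of a 2.7-fold higher number from compound 1 to compound 3 (0.43 log units; beyond the scatter) and a 4.7-fold higher number from compound 2 to compound 3 (0.67 log units; beyond the scatter) are both beyond the scatter, whereas a 1.7-fold lower number from compound 1 to compound 2 (0.24 log units; within the scatter) is within it.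

Compound 4 `CC(=O)Oc1ccccc1C(=O)O[C@H]1CO[C@H]2[C@@H]1OC[C@H]2OC(=O)c1cnccc1Cl` differs from compound 3 only at the aryl ester: 4-chloropyridin-3-yl in place of 3-methylphenyl on a carbonyl carbon. The measured steps that bear on this position are a 2.7-fold higher number from compound 1 to compound 3 (0.43 log units; beyond the scatter), a 4.7-fold higher number from compound 2 to compound 3 (0.67 log units; beyond the scatter) and a 1.7-fold lower number from compound 1 to compound 2 (0.24 log units; within the scatter), which show that changes at this carbonyl move this assay by modest amounts in either direction. Going by the values given here, no measured step replaces the carbon-only ring with a ring holding a hetero atom or a chlorine, so the direction is uncertain. A modest decrease is expected, since compound 3 holds the highest number and the two alternatives at this carbonyl both sit lower, giving an expected step of a 2.4-fold lower number from compound 3 to compound 4 (0.37 log units; beyond the scatter). Compound 4 is therefore estimated at 0.07 h, within a range of 0.025 h to 0.2 h.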

Compound 4, half-life: 0.0642 h
Estimate against measurement, compound 4: 1.1-fold (0.04 log units) above; the range from low to high includes it.
By their numbers in this assay, from the lowest: compounds 2, 1 and 4 (each within the scatter of the next); then compound 3.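

In this assay, the first ring at this carbonyl holding a hetero atom and a chlorine does not keep the number of the carbon-only 3-methylphenyl ring, with a 2.6-fold lower number from compound 3 to compound 4 (0.41 log units; beyond the scatter). Against the other two groups, the change stays within the scatter, with a 1.8-fold higher number from compound 2 to compound 4 (0.26 log units; within the scatter) and a 1.1-fold higher number from compound 1 to compound 4 (0.02 log units; within the scatter), so 4-chloropyridin-3-yl, 2-methylphenyl and ethyl cannot be told apart here and only 3-methylphenyl stands clear of the others. Nothing available accounts for this separation.

As far as these compounds go, how much of the step from 3-methylphenyl belongs to the ring nitrogen and how much to the chlorine remains open; pyridin-3-yl and 3-chlorophenyl at this carbonyl would separate the two. Also open, from the compounds shown here alone, is how an aminophenyl ring or a longer alkyl chain would read at this position.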